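Compound 3 to compound 4: replacing naphthalen-2-yl

A few compounds are considered here, and "the series" means these few. Any claim that something is new, unique, unknown or untested is made for them only; others in the source may bear on it.

Measured in a functional assay on MCF7 cells (Homo sapiens) for inhibition, read by MTT assay, with a stated time of 48 h; a higher number here means a weaker inhibitor, a lower number a stronger inhibitor:
- compound 1 `Oc1ccc(C(c2c[nH]c3ccc(Br)cc23)c2c[nH]c3ccc(Br)cc23)cc1`: 3500 nM
- compound 2 `COc1ccc(C(c2c[nH]c3ccc(Br)cc23)c2c[nH]c3ccc(Br)cc23)cc1`: 2300 nM
- compound 3 `Brc1ccc2[nH]cc(C(c3ccc4ccccc4c3)c3c[nH]c4ccc(Br)cc34)c2c1`: 7100 nM

Compound 3 stands highest of the three at 7100 nM, making it the weakest inhibitor measured so far. The next structure is compound 4 `Clc1ccc(C(c2c[nH]c3ccc(Br)cc23)c2c[nH]c3ccc(Br)cc23)cc1`, which carries 4-chlorophenyl in place of naphthalen-2-yl on a saturated chain carbon bound to two aromatic carbons.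

Two measured steps introduce naphthalen-2-yl at this place: a 2.0-fold higher number from compound 1 to compound 3 (0.31 log units; beyond the scatter), and a 3.1-fold higher number from compound 2 to compound 3 (0.49 log units; beyond the scatter). Both are modest. The remaining step, a 1.5-fold lower number from compound 1 to compound 2 (0.18 log units; within the scatter), shows no separation between the two single-ring compounds. Among the compounds with values here, no chlorinated compound has been measured, so the contribution of 4-chlorophenyl itself remains unknown. Leaving naphthalen-2-yl is therefore expected to bring a modest step towards a lower number in this assay, of similar size to the two steps above. The expected step is a 2.4-fold lower number from compound 3 to compound 4 (0.37 log units; beyond the scatter). The estimate for compound 4 is 3000 nM, with an expected range from 1300 nM to 7000 nM.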

Compound 4, half-maximal inhibitory concentration: 3500 nM
Estimate against measurement, compound 4: 1.2-fold (0.07 log units) below, within the range that was stated.
By their numbers in this assay, from the lowest: compounds 2, 1 and 4 (each within the scatter of the next); then compound 3.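

In this assay, chloro joins hydroxy and methoxy without separating from them: chloro in place of methoxy gives a 1.5-fold higher number from compound 2 to compound 4 (0.18 log units; within the scatter), and chloro in place of hydroxy gives no change at the digits printed from compound 1 to compound 4 (within the scatter). Replacing naphthalen-2-yl with 4-chlorophenyl gives a 2.0-fold lower number from compound 3 to compound 4 (0.31 log units; beyond the scatter), so compound 3 now stands apart from all three compounds with a single aromatic ring at this place, though only modestly, and none of the compounds shown goes against this. Nothing measured here gives a reason for these steps.

Still open, going by these compounds, is whether an amine or a carboxylic acid in place of chloro on an aromatic carbon would leave the number in the same range. Also open, on these data alone, is how an unsubstituted phenyl or a longer chain at the saturated chain carbon would compare.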